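Moving the Chlorine on the Phenyl Ring of Compound 2

This account rests on a few compounds, and the source may have more. Where it says the series, first, only, none or still open, it means among the compounds named here.

Going by the values given here, compound 2 `CCC1(C)CC(=O)N(CC(=O)N2CCN(c3ccccc3Cl)CC2)C1=O` is one of two compounds so far measured in a functional assay on the whole organism (strain CD1) with Mus musculus as the target, with a stated time of 3 s; on this read-out lower numbers stand for an effect already at smaller amounts and higher numbers for an effect only at larger amounts of compound. In this assay compound 2 gives 73.3 mg/kg, the lower of the two numbers. Its companion, compound 1 `CC1CC(=O)N(CC(=O)N2CCN(c3ccccc3Cl)CC2)C1=O`, carries hydrogen where compound 2 carries ethyl on the saturated ring carbon; in this assay compound 1 gives 152 mg/kg. Among the compounds with values here, the single step between measured compounds is a 2.1-fold lower number from compound 1 to compound 2 (0.32 log units; beyond the scatter), a modest gain on adding the ethyl group.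

Compound 3 `CCC1(C)CC(=O)N(CC(=O)N2CCN(c3ccc(Cl)cc3)CC2)C1=O` has not yet been measured. It differs from compound 2 in one place: 4-chlorophenyl in place of 2-chlorophenyl on an amine nitrogen in a ring. The two compounds share every atom and differ only in the chlorophenyl group that sits on the ring nitrogen of the six-membered non-aromatic ring with two nitrogens.

Within the data shown here, no measured step touches that chlorophenyl group; the one step that exists concerns the saturated ring carbon on the other side of the shared core and gives no guidance here. With nothing comparable to lean on, the expectation is a step of no size beyond the scatter, a 1.0-fold lower number from compound 2 to compound 3 (0.00 log units; within the scatter). Compound 3 is therefore estimated at 73 mg/kg, with a range from 35 mg/kg to 150 mg/kg.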

Compound 3, dose for half-maximal effect: 128 mg/kg
Compound 3: the middle estimate sits 1.8-fold (0.24 log units) below what was measured; the range from low to high includes it.
By their numbers in this assay, from the lowest: compounds 2, 3 and 1 (each within the scatter of the next, the first and the last beyond it).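

Going by these compounds alone, this is the first look at the chlorophenyl group on the amine nitrogen in the ring, and in this assay swapping 2-chlorophenyl for 4-chlorophenyl gives a 1.7-fold higher number from compound 2 to compound 3 (0.24 log units; within the scatter) on an otherwise unchanged structure. The two compounds have the same atoms joined differently, and this read-out does not separate them, so with this pair the placement of the chlorine on the phenyl ring shows no effect that can be told from the scatter, whereas the ethyl change earlier gave a 2.1-fold lower number from compound 1 to compound 2 (0.32 log units; beyond the scatter), which lies beyond it. Nothing available explains why the two chlorine placements read as they do.

Only these two placements of the chlorine are shown, so it remains open whether a plain phenyl, a fluorine or methoxy group in place of the chlorine, or a pyridine ring in place of the phenyl would move the number beyond the scatter. From the compounds shown here alone, it is also open whether ethyl in place of hydrogen on the saturated ring carbon would give a comparable step when the 4-chlorophenyl group is present.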